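The source may report more compounds than this note shows. Statements on the series, on what has been measured and on what is new or still open speak of the compounds shown alone.

Three compounds have been measured in a functional assay on Jurkat cells (Homo sapiens) for inhibition; a higher number here means a weaker inhibitor, a lower number a stronger inhibitor:
Compound 1, `CC(C)[C@H](NC(=O)COc1cccc2ccccc12)C(=O)N[C@@H](CC(=O)O)C(=O)COc1cc(C(F)(F)F)n(C)n1`, gives 46000 nM.
Compound 2, `CC(C)[C@H](NC(=O)COc1cccc2ccccc12)C(=O)N[C@@H](CC(=O)O)C(=O)CSc1nnc(-c2ccccc2)o1`, gives 150000 nM.
Compound 3, `Cc1nnc(SCC(=O)[C@H](CC(=O)O)NC(=O)[C@@H](NC(=O)COc2cccc3ccccc23)C(C)C)s1`, gives 190000 nM.

All three share the same core and differ only in the group attached to the saturated chain carbon bound to a carbonyl carbon. Compound 1 gives the lowest number of the three, so it is the strongest inhibitor of this small set, with compound 2 nearest to it and compound 3 furthest. Compound 4, `CC(C)[C@H](NC(=O)COc1cccc2ccccc12)C(=O)N[C@@H](CC(=O)O)C(=O)CSc1nnnn1-c1ccccc1`, has not yet been measured. Compared with compound 1 it differs in one place: (1-phenyl-1H-tetrazol-5-yl)sulfanyl in place of (1-methyl-5-(trifluoromethyl)-1H-pyrazol-3-yl)oxy on a saturated chain carbon bound to a carbonyl carbon. Within the data shown here, two measured steps bear on this change, since each of them also removes the (1-methyl-5-(trifluoromethyl)-1H-pyrazol-3-yl)oxy group at the same place in favour of a ring joined through a sulfanyl link: a 3.3-fold higher number from compound 1 to compound 2 (0.51 log units; beyond the scatter) and a 4.1-fold higher number from compound 1 to compound 3 (0.62 log units; beyond the scatter). Both weakened inhibition by a modest, similar amount, and the two sulfur-linked rings gave numbers within the scatter of each other, as a 1.3-fold higher number from compound 2 to compound 3 (0.10 log units; within the scatter) shows. A step of the same kind and direction is therefore expected here, an increase in the number of a 3.5-fold higher number from compound 1 to compound 4 (0.54 log units; beyond the scatter). Compound 4 is thus estimated at 160000 nM in this assay, with a range of 70000 nM to 360000 nM.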

Compound 4, half-maximal inhibitory concentration: 153000 nM
Beside the measured number, compound 4's estimate is 1.0-fold (0.02 log units) above it; measured number inside the range.
By their numbers in this assay, from the lowest: compound 1; then compounds 2, 4 and 3 (each within the scatter of the next).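

The change at this saturated chain carbon bound to a carbonyl carbon now has a third sulfur-linked ring behind it, and in this assay the result is again a modest loss, with a 3.3-fold higher number from compound 1 to compound 4 (0.52 log units; beyond the scatter) matching the size of the two earlier steps away from the oxygen-linked pyrazole. The new ring also shows how little the choice of ring on the sulfur has mattered so far: a 1.0-fold higher number from compound 2 to compound 4 (0.01 log units; within the scatter) and a 1.2-fold lower number from compound 3 to compound 4 (0.09 log units; within the scatter) both stay within the scatter, even though 1-phenyl-1H-tetrazol-5-yl brings a five-membered aromatic ring with 4 hetero atoms plus a six-membered aromatic ring of carbon only. Among the compounds shown, all three sulfur-linked compounds therefore sit together and only compound 1 stands apart, with none going against that grouping.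

Going by these compounds, compound 1 differs from the others in both the linking atom and the ring, so it remains open which of the two accounts for the step, and how a 1-methyl-5-(trifluoromethyl)-1H-pyrazol-3-yl ring on sulfur, or an amine at this place, would read. Nothing measured here explains why the sulfur-linked compounds group together.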